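Toward compound 4: benzoyl in place of methoxycarbonyl

The source may report more compounds than this note shows. Statements on the series, on what has been measured and on what is new or still open speak of the compounds shown alone.

Measured so far in a physicochemical assay for acid dissociation:
- compound 1 `COC(=O)CC1c2ccc(Cl)cc2NC(=O)C1C(=O)OC` gives > 11 (a limit)
- compound 2 `COC(=O)CC1c2ccc(Cl)cc2NC(=O)C1S(C)(=O)=O` gives > 11 (a limit)
- compound 3 `COC(=O)CC1c2ccc(Cl)cc2NC(=O)C1S(=O)(=O)c1ccccc1` gives 10.8

Compound 1 has only a limit in this assay and no number. It stands at the limit of > 11 in this assay, at which 2 of the 3 values shown sit.

The next compound is compound 4 `COC(=O)CC1c2ccc(Cl)cc2NC(=O)C1C(=O)c1ccccc1`, which carries phenyl in place of methoxy on a carbonyl carbon, so that methoxycarbonyl becomes benzoyl: phenyl in place of methoxy on a carbonyl carbon.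

Among the measured compounds shown here, two measured steps bear on this change, and neither gives it a firm size. The same methoxycarbonyl was replaced in a step that the two limits leave unreadable from compound 1 to compound 2, with methylsulfonyl as the incoming group. For the measured compounds named here, only one measured step brings in a phenyl: a number at least 0.20 log units lower from compound 2 to compound 3 (that floor lies within the scatter). There the phenyl replaces methyl on a sulfonyl sulfur, whereas in compound 4 it sits on a carbonyl carbon, so the transfer is loose.

On that step, a modest move to a lower number is expected in this assay, and it may not clear the limit of the starting compound. The expected step is a number at least 0.50 log units lower from compound 1 to compound 4 (beyond the scatter).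

The estimate for compound 4 is 10.5, with an expected range from 9.7 to 11.2.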

Compound 4, acid dissociation constant: about 9
Beside the measured number, compound 4's estimate is 1.50 log units above it; measured number below the stated range.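

In this assay, among the compounds shown here, phenyl in place of methoxy on a carbonyl carbon gives a number at least 2.00 log units lower from compound 1 to compound 4 (beyond the scatter), and benzoyl in place of methylsulfonyl on a saturated ring carbon gives a number at least 2.00 log units lower from compound 2 to compound 4 (beyond the scatter), the first changes on this saturated ring carbon that read clearly beyond the scatter. Both steps start from a limit and are therefore floors, not full sizes: the limit of > 11 in this assay, at which 2 of the 4 values shown sit. For the compounds shown here, the only earlier phenyl step, on a sulfonyl sulfur, gave a number at least 0.20 log units lower from compound 2 to compound 3 (that floor lies within the scatter), and with compound 3 at 10.8 and compound 4 at about 9, the large step in these compounds goes with phenyl on a carbonyl carbon, not with a phenyl on any group.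

As far as these compounds go, it remains open whether the carbonyl or the phenyl carries the step, a question that acetyl or nitrobenzoyl on the same saturated ring carbon would help to separate. From the compounds shown here alone, the step from compound 1 to compound 2 cannot be read, and the true sizes of the steps that start from the two limits remain unknown.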